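The source may report more compounds than this note shows. Statements on the series, on what has been measured and on what is new or still open speak of the compounds shown alone.

Of the compounds shown here, three have been measured in a functional assay on thoracic aorta (Rattus norvegicus, strain Wistar), with a stated time of 15 min; a higher number here means that more compound is needed for the effect, a lower number that less compound is needed. Compound 3 `CCOc1ccc(Br)cc1C(C)NC(=O)N(C)S(=O)(=O)c1ccccc1` gives 19800 nM in this assay. Compound 2 `CCOc1ccc(Br)cc1C(C)NC(=O)NS(=O)(=O)c1ccccc1` differs from compound 3 by hydrogen in place of methyl on an amide-type nitrogen. In this assay compound 2 reaches only a limit, > 300000 nM. That change gave an at least 15-fold higher number from compound 3 to compound 2 (1.18 log units; beyond the scatter), and the size of this step rests on (the limit of > 300000 nM in this assay, at which 1 of the 3 values shown sits), so only its lower bound is known. Compound 1 `Cc1ccc(S(=O)(=O)N(C)C(=O)NC(C)c2cc(C)ccc2OCc2ccccc2)cc1` belongs to a different core, and the difference between the two cores is not broken down here; in this assay compound 1 gives 181000 nM, the highest of the two numbers, with compound 3 the nearest to it.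

Compound 4 `Cc1ccc(S(=O)(=O)NC(=O)NC(C)c2cc(C)ccc2OCc2ccccc2)cc1` has not yet been measured. It differs from compound 1 by hydrogen in place of methyl on an amide-type nitrogen, the same change as the one leading from compound 3 to compound 2, a change found in two places among these compounds. Since compound 1 already stands close to the limit of this assay and the earlier step was an at least 15-fold higher number from compound 3 to compound 2 (1.18 log units; beyond the scatter), the step expected in this assay is an 11-fold higher number from compound 1 to compound 4 (1.04 log units; beyond the scatter). Compound 4 is therefore estimated at 2000000 nM in this assay, with the range expected to run from 400000 nM to 10000000 nM, and it is thought likely that this assay will report only a limit for compound 4.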

Compound 4, half-maximal effective concentration: 91900 nM
Compound 4: middle estimate off by 22-fold (1.34 log units), on the high side; measured number outside the range, below it.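

In this assay, among these compounds, hydrogen in place of methyl on the amide-type nitrogen whose other neighbours are the carbonyl carbon and the sulfonyl sulfur gave a 2.0-fold lower number from compound 1 to compound 4 (0.29 log units; within the scatter), so on the core of compound 1 this change produced no step that can be told from the scatter. The change therefore did not carry over from one core to the other with the same size, and a step seen on one core in this series cannot simply be transferred to the other: the same change on two cores in this assay, an at least 15-fold higher number (1.18 log units; beyond the scatter) from compound 3 to compound 2 and a 2.0-fold lower number (0.29 log units; within the scatter) from compound 1 to compound 4, at least 29-fold (1.47 log units) apart, beyond the scatter of two such steps With only two cores, this does not show which of the differences between them goes with the difference between the steps, nor how the change would behave on a third core, and the earlier step is known only as a lower bound, with compound 2 at a limit: the limit of > 300000 nM in this assay, at which 1 of the 4 values shown sits.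

The compounds shown leave open which of the several places where the two cores differ matters, as no pair among them separates those places one at a time. They also leave open what a longer chain such as ethyl, or a group such as a carboxylic acid, on the same nitrogen would do in this assay.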